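The source may hold more compounds than are shown below. What is called first, only, known or untested is meant among the compounds shown, and "the series" means these compounds.

The series keeps one acyl chain, a long unsaturated chain ending in a carbonyl, and varies only what sits on the other side of that carbonyl. In an assay on isolated protein for inhibition of Fatty-acid amide hydrolase 1 (Homo sapiens) (a higher number here means a weaker inhibitor, a lower number a stronger inhibitor), compound 1 `CCCCCCCC/C=C\CCCCCCC(=O)c1ncc(-c2ccccc2)o1` gives 320 nM, and compound 3 `CCCCCCCC/C=C\CCCCCCC(=O)c1nc(-c2ccccn2)co1` gives 31 nM. Compound 2 `CCCCCCCC/C=C\CCCCCCC(=O)c1ccccc1`, where the carbonyl carries a plain phenyl, reaches only the limit of this assay, > 100000 nM, so for compound 2 the numbers give a limit and not a measured value; it sits at the limit of > 100000 nM in this assay, at which 1 of the 3 values shown sits. Compound 4 `CCCCCCCC/C=C\CCCCCCC(=O)c1nc2ccccc2o1` differs from compound 2 in one place: 1,3-benzoxazol-2-yl in place of phenyl on a carbonyl carbon. For the measured compounds named here, no step between measured compounds covers this pair, so what can be said rests on the contrast between compound 2 at its limit and the numbers of compound 1 and compound 3. On that basis compound 4 is expected to move well beyond the scatter toward stronger inhibition, the expected step being an at least 500-fold lower number from compound 2 to compound 4 (2.69 log units; beyond the scatter). Compound 4 is estimated to give about 200 nM in this assay, with a plausible range from 30 nM to 1500 nM.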

Compound 4, inhibition constant: 370 nM
Beside the measured number, compound 4's estimate is 1.9-fold (0.27 log units) below it; the measured number falls inside the stated range.
By their numbers in this assay, from the lowest: compound 3; then compounds 1 and 4 (each within the scatter of the next). At a limit, above all of these: compound 2.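

In this assay, for the compounds shown here, 1,3-benzoxazol-2-yl in place of phenyl on a carbonyl carbon gives an at least 270-fold lower number from compound 2 to compound 4 (2.43 log units; beyond the scatter), the first one-place change that can be read as a step, and it shows that this position tolerates no simple swap of one aromatic group for another. On these data alone, compound 2 stays a limit and not a number, so the full size of the step remains unknown: the limit of > 100000 nM in this assay, at which 1 of the 4 values shown sits. The entering group adds a five-membered aromatic ring with 2 hetero atoms and 2 hydrogen-bond acceptors, and this single step cannot separate those features from one another.

Which of them carries the step remains open, and a benzothiazol-2-yl or a pyridin-2-yl on the same carbonyl carbon would speak to that. As far as these compounds go, whether the step holds on a shorter saturated chain also remains open.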